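The compounds below may be only part of what the source reports. "The series", "measured", "known", "first", "only" and "open" are said of these compounds alone.

In an ADME assay on BHK-21 cells (Mesocricetus auratus) for cytotoxicity, read by MTT assay, with a stated time of 72 h (a higher number here means that more compound is tolerated, a lower number that less compound is tolerated), compound 1 `Cc1ccccc1C1CC(c2ccc(OCc3ccccc3)cc2)=NN1c1ccc(S(N)(=O)=O)cc1` gives 20000 nM, compound 2 `Cc1ccc(C2CC(c3ccc(OCc4ccccc4)cc3)=NN2c2ccc(S(N)(=O)=O)cc2)cc1` gives 32000 nM and compound 3 `NS(=O)(=O)c1ccc(N2N=C(c3ccc(OCc4ccccc4)cc3)CC2c2ccccc2F)cc1` gives 90000 nM, the highest of the three numbers. Compound 4 `NS(=O)(=O)c1ccc(N2N=C(c3ccc(Oc4ccccc4)cc3)CC2c2ccccc2F)cc1` differs from compound 3 in one place: phenyl in place of benzyl on an oxygen on an aromatic ring. In short, the benzyloxy group of compound 3 becomes a phenoxy group in compound 4. Among the compounds with values here, no measured step makes this change. All three lie elsewhere in the molecule: a 1.6-fold higher number from compound 1 to compound 2 (0.20 log units; within the scatter) is within the scatter, while a 4.5-fold higher number from compound 1 to compound 3 (0.65 log units; beyond the scatter) and a 2.8-fold higher number from compound 2 to compound 3 (0.45 log units; beyond the scatter) are modest. These steps show how far this assay can move, but give no direction here, so no step beyond the scatter is expected. The expected change is a 1.5-fold lower number from compound 3 to compound 4 (0.18 log units; within the scatter). For compound 4 the estimated value is 60000 nM, with an expected range of 20000 nM to 150000 nM.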

Compound 4, half-maximal cytotoxic concentration: 32000 nM
For compound 4 the middle estimate is 1.9-fold (0.27 log units) above the measured one; measured number inside the range.
By their numbers in this assay, from the lowest: compounds 1, 2 and 4 (each within the scatter of the next); then compound 3.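

At this oxygen on an aromatic ring, phenyl in place of benzyl gives a 2.8-fold lower number from compound 3 to compound 4 (0.45 log units; beyond the scatter) in this assay. Within the data shown here, this is the first measured change at this place, and it shows that this end of the molecule can also shift how much compound is tolerated. Nothing available explains the drop.

On these data alone, whether the same drop would appear with 2-methylphenyl or 4-methylphenyl on the saturated ring carbon remains open. So does the reading for a longer chain on the oxygen, or for an amine on the aromatic ring.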